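Swapping Isopropyl for Methyl on a Chloro Analogue

This account rests on a few compounds, and the source may have more. Where it says the series, first, only, none or still open, it means among the compounds named here.

Measured so far in a functional assay on DU-145 cells (Homo sapiens) for cytotoxicity, read by MTT assay, with a stated time of 48 h; a higher number here means a weaker inhibitor, a lower number a stronger inhibitor:
Compound 1 `CC(C)n1c(/C=C2/C(=O)Nc3ccc(Br)cc32)nc2ccccc21` gives 7500 nM.
Compound 2 `Cn1c(/C=C2/C(=O)Nc3ccc(Br)cc32)nc2ccccc21` gives 39600 nM.
Compound 3 `CC(C)n1c(/C=C2/C(=O)Nc3ccc(Cl)cc32)nc2ccccc21` gives 36400 nM.

Compound 4 `Cn1c(/C=C2/C(=O)Nc3ccc(Cl)cc32)nc2ccccc21` is not yet measured. The change that makes compound 4 from compound 3 is methyl in place of isopropyl on an aromatic nitrogen. The same change has already been measured once, from compound 1 to compound 2, where it is methyl in place of isopropyl on an aromatic nitrogen and gave a 5.3-fold higher number from compound 1 to compound 2 (0.72 log units; beyond the scatter). The two starting points differ in their cores by chloro in place of bromo on an aromatic carbon, which on its own gave a 4.9-fold higher number from compound 1 to compound 3 (0.69 log units; beyond the scatter). Because the earlier step of a 5.3-fold higher number from compound 1 to compound 2 (0.72 log units; beyond the scatter) was modest and beyond the scatter, a step of similar size is expected here for compound 4, namely a 3.0-fold higher number from compound 3 to compound 4 (0.48 log units; beyond the scatter), though with a single precedent the expectation is loose. Compound 4 is thus estimated at 110000 nM.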

Compound 4, half-maximal inhibitory concentration: 38900 nM
Compound 4: the middle estimate sits 2.8-fold (0.45 log units) above what was measured; low and high end bracket the measured number.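

In this assay, methyl in place of isopropyl on the chloro core gives a 1.1-fold higher number from compound 3 to compound 4 (0.03 log units; within the scatter), so this change does not carry over unchanged from the bromo core: the same change on two cores in this assay, a 5.3-fold higher number (0.72 log units; beyond the scatter) from compound 1 to compound 2 and a 1.1-fold higher number (0.03 log units; within the scatter) from compound 3 to compound 4, 4.9-fold (0.69 log units) apart, beyond the scatter of two such steps
Chloro in place of bromo likewise depends on the group on the aromatic nitrogen, and on the methyl core it gives a 1.0-fold lower number from compound 2 to compound 4 (0.01 log units; within the scatter), so the two changes do not simply add up: the same change on two cores in this assay, a 4.9-fold higher number (0.69 log units; beyond the scatter) from compound 1 to compound 3 and a 1.0-fold lower number (0.01 log units; within the scatter) from compound 2 to compound 4, 4.9-fold (0.69 log units) apart, beyond the scatter of two such steps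
This shows that a step measured on one core is a poor guide to the other here, but it does not show why, and it rests on these four compounds alone.

Going by these compounds, whether an ethyl group or a longer chain on the aromatic nitrogen would follow compound 1 or compound 3 remains open. So does the effect of fluoro or methoxy in place of bromo.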